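Bromo to chloro at the aryl ring: compound 1 to compound 4

This account rests on a few compounds, and the source may have more. Where it says the series, first, only, none or still open, it means among the compounds named here.

Compound 1 `CCCc1cc(N)c2cc(NC(=O)/C=C/c3ccc(Br)cc3)ccc2n1` gives 4 nM in an assay on isolated protein for displacement of a labelled ligand from melanin-concentrating hormone receptor 1 (Homo sapiens) (on this read-out lower numbers stand for stronger inhibition and higher numbers for weaker inhibition), the second highest of the three numbers recorded so far. Compound 2 `Cc1cc(N)c2cc(NC(=O)/C=C/c3ccc(C(F)(F)F)cc3)ccc2n1` gives 8 nM, within the scatter of compound 1; compound 3 `CCc1cc(N)c2cc(NC(=O)/C=C/c3ccc(C(F)(F)F)cc3)ccc2n1` gives 1.2 nM, beyond the scatter and lower than compound 1. Among the compounds with values here, the only single-place step among the measured compounds is a 6.7-fold lower number from compound 2 to compound 3 (0.82 log units; beyond the scatter), and it concerns the chain on the shared core, not the substituent on the aryl ring.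

Compound 4 `CCCc1cc(N)c2cc(NC(=O)/C=C/c3ccc(Cl)cc3)ccc2n1` differs from compound 1 in one place: chloro in place of bromo on an aromatic carbon. Within the data shown here, no measured pair varies this position alone, so no recorded step bears directly on it. Compounds 1 and 2 carry different groups at this ring position and sit within the scatter of each other, but they also differ in the chain, so that pair cannot be read as a change at the ring alone. The expected step is therefore a 1.5-fold higher number from compound 1 to compound 4 (0.18 log units; within the scatter), not beyond the scatter. Compound 4 is estimated at 6 nM, with a range from 2.5 nM to 15 nM.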

Compound 4, half-maximal inhibitory concentration: 6 nM
Compound 4: the middle estimate sits on the measured number at the digits printed, and the stated range covers the measured number.
By their numbers in this assay, from the lowest: compound 3; then compounds 1, 4 and 2 (each within the scatter of the next).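

In this assay, within the data shown here, the change from 4-bromophenyl to 4-chlorophenyl gives the first reading in which this ring position varies alone: a 1.5-fold higher number from compound 1 to compound 4 (0.18 log units; within the scatter). Among these compounds, on the chain of compound 1, the two halogens therefore cannot be told apart on this read-out, whereas the only earlier single-place step, a 6.7-fold lower number from compound 2 to compound 3 (0.82 log units; beyond the scatter), concerns the chain and lies beyond the scatter. No measurement here bears on why bromo and chloro read alike.

Trifluoromethyl appears only in compounds 2 and 3, neither of which shares the chain of compound 1, so its standing against the halogens at this ring position stays open. Also open, going by these compounds, is whether fluoro, methoxy, a nitrile or an amine on this aromatic carbon, or a longer chain on the shared core, would stay within the scatter of compound 1.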